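Swapping tert-butyl for bromo on the aromatic ring

The source may hold more compounds than are shown below. What is called first, only, known or untested is meant among the compounds shown, and "the series" means these compounds.

Measured so far in a functional assay on HeLa cells (Homo sapiens) for cytotoxicity, read by MTT assay, with a stated time of 48 h (a higher number here means a weaker inhibitor, a lower number a stronger inhibitor), are three compounds:
- Compound 1 `CC1(C)CCC[C@]2(C)[C@@H](CC[C@@](C)(O)/C=C/c3ccccc3)[C@](C)(O)CC[C@@H]12` gives 3320 nM
- Compound 2 `CC1(C)CCC[C@]2(C)[C@@H](CC[C@@](C)(O)/C=C/c3cccc([N+](=O)[O-])c3)[C@](C)(O)CC[C@@H]12` gives 3380 nM
- Compound 3 `CC(C)(C)c1ccc(/C=C/[C@](C)(O)CC[C@@H]2[C@@]3(C)CCCC(C)(C)[C@@H]3CC[C@@]2(C)O)cc1` gives 48500 nM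

Compound 3 has the highest number of the three, which makes it the weakest inhibitor here. Compound 4 `CC1(C)CCC[C@]2(C)[C@@H](CC[C@@](C)(O)/C=C/c3ccc(Br)cc3)[C@](C)(O)CC[C@@H]12` carries bromo in place of tert-butyl on an aromatic carbon and has not been measured. Two steps show what tert-butyl went with, a 15-fold higher number from compound 1 to compound 3 (1.16 log units; beyond the scatter) and a 14-fold higher number from compound 2 to compound 3 (1.16 log units; beyond the scatter), while nitro made no real difference, a 1.0-fold higher number from compound 1 to compound 2 (0.01 log units; within the scatter). For the measured compounds named here, no bromo compound has been measured, so most, but perhaps not all, of the tert-butyl step should reverse. In this assay the expected change is a large drop, an 8.1-fold lower number from compound 3 to compound 4 (0.91 log units; beyond the scatter) as estimated. Compound 4 is expected at 6000 nM with 1800 nM to 22000 nM as its likely range.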

Compound 4, half-maximal inhibitory concentration: 45900 nM
Compound 4: middle estimate off by 7.7-fold (0.88 log units), on the low side; measured number outside the range, above it.
By their numbers in this assay, from the lowest: compounds 1 and 2 (each within the scatter of the next); then compounds 4 and 3 (each within the scatter of the next).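

In this assay, bromo and tert-butyl on this aromatic carbon cannot be told apart, a 1.1-fold lower number from compound 3 to compound 4 (0.02 log units; within the scatter), although bromo has one heavy atom and tert-butyl has four. The large rise seen with tert-butyl is therefore not unique to that group: bromo in place of hydrogen gives a 14-fold higher number from compound 1 to compound 4 (1.14 log units; beyond the scatter), and the 4-bromophenyl group in place of the nitro-bearing ring gives a 14-fold higher number from compound 2 to compound 4 (1.13 log units; beyond the scatter). Nothing available here explains this shared rise. As far as these compounds go, whether an amine or a carboxylic acid on this carbon would also give such a high number remains open.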